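The compounds below may be only part of what the source reports. "The series", "measured", "known", "first", "only" and "open" are said of these compounds alone.

Compound 1 `COc1ccc(-c2cnc3nc(N)nc(N4CCN(C(=O)Nc5ccc(C)cc5)CC4)c3n2)cc1OC` and compound 2 `COc1ccc(-c2cnc3nc(N)nc(N4CCN(C(=O)NCc5ccc(F)cc5)CC4)c3n2)cc1OC` share one core and differ only at an amide-type nitrogen. In a functional assay on cells (T-cell, Homo sapiens) for inhibition (a higher number here means a weaker inhibitor, a lower number a stronger inhibitor), compound 1 gives 0.8 nM, while compound 2 gives 37 nM. Among the measured compounds shown here, the one step between them, a 46-fold higher number from compound 1 to compound 2 (1.67 log units; beyond the scatter), set 4-fluorobenzyl in place of 4-methylphenyl on that nitrogen. For the measured compounds named here, compound 2 thus stands highest of the two numbers in this assay, with compound 1 as its only neighbour. Compound 3 `COc1ccc(-c2cnc3nc(N)nc(N4CCN(C(=O)Nc5ccc(F)cc5)CC4)c3n2)cc1OC` is not yet measured and differs from compound 2 in one place: 4-fluorophenyl in place of 4-fluorobenzyl on an amide-type nitrogen. Of the measured steps only a 46-fold higher number from compound 1 to compound 2 (1.67 log units; beyond the scatter) bears on this change, and it covers it only in part: that step moved from 4-methylphenyl to 4-fluorobenzyl, not from 4-fluorobenzyl to 4-fluorophenyl alone. Going by the values given here, no step isolating that change exists here. A large drop is nonetheless expected for compound 3, of a 15-fold lower number from compound 2 to compound 3 (1.17 log units; beyond the scatter). Compound 3 is estimated in this assay at 2.5 nM, within a range from 0.6 nM to 12 nM.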

Compound 3, half-maximal inhibitory concentration: 7 nM
Compound 3: middle estimate off by 2.8-fold (0.45 log units), on the low side; the range from low to high includes it.
By their numbers in this assay, from the lowest: compound 1; then compound 3; then compound 2.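

In this assay, 4-fluorophenyl in place of 4-fluorobenzyl on the amide-type nitrogen gives a 5.3-fold lower number from compound 2 to compound 3 (0.72 log units; beyond the scatter) and so isolates this change, with the fluoro group present on both sides. Fluoro in place of methyl on an aromatic carbon gives an 8.8-fold higher number from compound 1 to compound 3 (0.94 log units; beyond the scatter), showing that the earlier 46-fold higher number from compound 1 to compound 2 (1.67 log units; beyond the scatter) combined two changes, each beyond the scatter on its own. No measured evidence is available to explain either step.

The compounds shown leave open whether chloro or methoxy in place of fluoro on that aromatic carbon would give a lower or higher number, and whether a longer chain such as 2-phenylethyl on the nitrogen would raise the number further. They also leave open whether 4-methylbenzyl would show a step like that seen with the fluoro pair.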